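A Pyridin-4-yl Swap on an Unmeasured Hydroxyphenyl Compound

A few compounds are considered here, and "the series" means these few. Any claim that something is new, unique, unknown or untested is made for them only; others in the source may bear on it.

Among the compounds with values here, in a functional assay on MCF7 cells (Homo sapiens) for antiproliferative activity, with a stated time of 5 days (on this read-out higher numbers stand for weaker inhibition and lower numbers for stronger inhibition), compound 1 (`CCCCc1ccc2[nH]c(-c3ccc(OC)cc3)c(/C=N/NC(=O)c3ccc(Cl)cc3)c2c1`) gives 220 nM, and this is the only number available for the series. Compound 2 (`CCCCc1ccc2[nH]c(-c3ccc(OC)cc3)c(/C=N/NC(=O)c3cccc(O)c3)c2c1`) has no number to stand on. Its entry in this assay reads "not determined" (no result reported), so it can be ranked neither ahead of nor behind compound 1.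

Compound 3 (`CCCCc1ccc2[nH]c(-c3ccc(OC)cc3)c(/C=N/NC(=O)c3ccncc3)c2c1`) has yet to be measured. The structural change is pyridin-4-yl in place of 3-hydroxyphenyl on a carbonyl carbon, which puts pyridin-4-yl in place of 3-hydroxyphenyl on a carbonyl carbon, while the rest of the molecule stays as it was. Within the data shown here, without a number for compound 2, this change has no measured starting point, and the series offers no measured step from which to judge its size or direction. Among the measured compounds shown here, the only anchor is therefore compound 1 at 220 nM, and compound 3 is expected to fall within the usual scatter of that value, with no direction favoured by the data. The range is kept wide, as it rests on a single measurement. In this assay, the estimate for compound 3 is 280 nM, with an expected range of 80 nM to 1000 nM.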

Compound 3, half-maximal inhibitory concentration: 69 nM
Beside the measured number, compound 3's estimate is 4.1-fold (0.61 log units) above it; measured number below the stated range.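

In this assay the group on the carbonyl carbon changes from 4-chlorophenyl to pyridin-4-yl, and this gives a 3.2-fold lower number from compound 1 to compound 3 (0.50 log units; beyond the scatter) in the read-out, the first measured sign that this position responds to the group placed on it. The step from compound 2 to compound 3 cannot be read: compound 2 has no number, so replacing 3-hydroxyphenyl with pyridin-4-yl still has neither a size nor a direction. No measurement at hand bears on why the pyridin-4-yl compound reads lower than the 4-chlorophenyl compound.

The compounds shown leave open whether a plain phenyl or a pyridin-3-yl group on the same carbonyl carbon would give a number nearer to compound 1 or to compound 3, and so whether the ring nitrogen, its place in the ring or the absence of chlorine goes with the step. They also leave open how a pyridin-4-yl ring carrying an amine or a carboxylic acid would read in this assay, and one readable step sets no trend for this position.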